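A few compounds are considered here, and "the series" means these few. Any claim that something is new, unique, unknown or untested is made for them only; others in the source may bear on it.

Measured compounds:
compound 1, `CCCCNC(=O)Oc1cccc(-n2ccc(C(N)=O)c2)c1`, in an assay (brain) for inhibition of Fatty-acid amide hydrolase 1 (Mus musculus), with stated times of 20 min and 15 min (on this read-out lower numbers stand for stronger inhibition and higher numbers for weaker inhibition), compound 1 gives 240 nM
compound 2, `NC(=O)c1ccn(-c2cccc(OC(=O)NCCCCCCc3ccccc3)c2)c1`, in this assay compound 2 gives 0.6 nM

Compound 2 holds the lowest number of the two shown, and the step of a 400-fold lower number from compound 1 to compound 2 (2.60 log units; beyond the scatter) separates it from compound 1 by a wide margin. Compound 3, `Cc1cc(C(N)=O)c(-c2cccc(OC(=O)NCCCCCCc3ccccc3)c2)o1`, keeps the whole chain of compound 2 and alters only the aromatic substituent: 3-carbamoyl-5-methylfuran-2-yl in place of 3-carbamoyl-1H-pyrrol-1-yl on an aromatic carbon. Among the compounds with values here, this is a different kind of change from the one measured step, which replaced a hydrogen on the saturated chain with phenethyl and left the heterocycle untouched. Within the data shown here, no measured step therefore bears directly on the exchange of one carbamoyl-bearing five-membered ring for another, and the expectation for compound 3 rests on the value of compound 2 alone. Because compound 2 gives 0.6 nM with the same chain, compound 3 is expected to stay in a similar region, with the estimated step of a 3.3-fold higher number from compound 2 to compound 3 (0.52 log units; beyond the scatter) leaning toward a somewhat higher number. For compound 3 the estimate in this assay is 2 nM, within a range from 0.3 nM to 15 nM.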

Compound 3, half-maximal inhibitory concentration: 1.7 nM
Compound 3: the middle estimate sits 1.2-fold (0.07 log units) above what was measured; the range from low to high includes it.
By their numbers in this assay, from the lowest: compound 2; then compound 3; then compound 1.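

The ring on this aromatic carbon can be exchanged with only a limited change in the read-out: in this assay, the step is a 2.8-fold higher number from compound 2 to compound 3 (0.45 log units; beyond the scatter), which is beyond the usual scatter but modest in size. The earlier compounds shown here showed only what happens along the chain, where the step was a 400-fold lower number from compound 1 to compound 2 (2.60 log units; beyond the scatter), and they gave no view of this position, meta to a large group. Compound 3 now shows that 3-carbamoyl-5-methylfuran-2-yl can take the place of 3-carbamoyl-1H-pyrrol-1-yl while the number stays low, although nothing given here explains why the number rises in this exchange.

Going by these compounds, this single step replaces the pyrrole-type ring with a furan-type ring, moves the point of attachment and adds a methyl group all at once, so the share of each change in the result remains open. On these data alone, it also remains open how a thiophene ring bearing the same carbamoyl group, or a carboxylic acid in place of the carbamoyl group, would read in this assay.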